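Rigidifying the Hydroxamate Arm of a Nicotinamide Phosphoribosyltransferase Inhibitor

This account rests on a few compounds, and the source may have more. Where it says the series, first, only, none or still open, it means among the compounds named here.

Measured compounds:
compound 1, `CC(C)CCN(CCCCCCC(=O)NO)c1ncc(C(=O)NCc2cccnc2)s1`, 220 nM
compound 2, `O=C(CCCCCCCN(Cc1ccc(F)cc1)c1ncc(C(=O)NCCCn2ccnc2)s1)NO`, 18 nM

In an assay on isolated protein for inhibition of Nicotinamide phosphoribosyltransferase (Homo sapiens), read by fluorescence, with stated times of 5 min and 15 min (a lower number here means a stronger inhibitor, a higher number a weaker inhibitor), compound 2 gives the lower of the two numbers, with compound 1 showing a step beyond the scatter. Compound 3, `O=C(/C=C/c1ccc(CN(Cc2ccc(F)cc2)c2ncc(C(=O)NCCCn3ccnc3)s2)cc1)NO`, differs from compound 2 by 4-(2-(hydroxycarbamoyl)ethenyl)phenyl in place of 6-(hydroxycarbamoyl)hexyl on a saturated chain carbon bound to a nitrogen on an aromatic ring. Going by the values given here, with no comparable step among the measured compounds, the authors expect a modest weakening, estimated as a 2.2-fold higher number from compound 2 to compound 3 (0.35 log units; beyond the scatter), close to the edge of the scatter. Compound 3 is therefore estimated at 40 nM, within 10 nM to 200 nM.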

Compound 3, half-maximal inhibitory concentration: 14 nM
Estimate against measurement, compound 3: 2.9-fold (0.46 log units) above, within the range that was stated.
By their numbers in this assay, from the lowest: compounds 3 and 2 (each within the scatter of the next); then compound 1.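

In this assay, 4-(2-(hydroxycarbamoyl)ethenyl)phenyl in place of 6-(hydroxycarbamoyl)hexyl gives a 1.3-fold lower number from compound 2 to compound 3 (0.11 log units; within the scatter), and this step lies within the scatter. This position, a saturated chain carbon bound to a nitrogen on an aromatic ring, therefore tolerates an arm containing a six-membered aromatic ring of carbon only, which compound 1 and compound 2 could not show. Nothing available explains this result. Still open, as far as these compounds go, is how this assay would respond to a carboxylic acid in place of the hydroxycarbamoyl group, or to a cyclohexane ring in place of the phenyl ring.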